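Dropping the Chloro Group: From Compound 3 to Compound 4

The source may report more compounds than this note shows. Statements on the series, on what has been measured and on what is new or still open speak of the compounds shown alone.

Compound 1 `O=C(Nc1nnc(-c2cccc(O)c2O)s1)c1ccccc1`: 22300 nM
Compound 2 `O=C(Nc1nnc(-c2cccc(O)c2O)s1)C1CCCCC1`: 19900 nM
Compound 3 `O=C(Nc1nnc(-c2ccc(O)c(O)c2)s1)c1ccc(Cl)cc1`: 53000 nM

In a functional assay, with a stated time of 30 min, in the absence of a further agent (on this read-out lower numbers stand for stronger inhibition and higher numbers for weaker inhibition), compound 3 gives the highest of the three numbers; compound 1 and compound 2 both sit lower, beyond the usual scatter, while the step of a 1.1-fold lower number from compound 1 to compound 2 (0.05 log units; within the scatter) lies within it. Compound 4 `O=C(Nc1nnc(-c2ccc(O)c(O)c2)s1)c1ccccc1` differs from compound 3 by hydrogen in place of chloro on an aromatic carbon. Among the measured compounds shown here, no measured step addresses this change: the one measured step alters the group on the carbonyl carbon, not the 4-chlorophenyl, and compound 1 differs from compound 3 in more than one place, so its value shows only that a different arrangement gives a lower number. Compound 4 is therefore expected to show a 1.2-fold lower number from compound 3 to compound 4 (0.07 log units; within the scatter), nothing beyond the scatter, with an estimated 45000 nM between 20000 nM and 100000 nM.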

Compound 4, half-maximal inhibitory concentration: 23400 nM
Compound 4: middle estimate off by 1.9-fold (0.28 log units), on the high side; measured number inside the range.
By their numbers in this assay, from the lowest: compounds 2, 1 and 4 (each within the scatter of the next); then compound 3.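

In this assay, among the compounds shown here, the step of a 2.3-fold lower number from compound 3 to compound 4 (0.36 log units; beyond the scatter) is the first measured change on this aromatic ring, and it lies beyond the scatter. The chloro, on an aromatic carbon para to a large group, therefore has a readable if modest bearing on the number, with the phenyl compound inhibiting more strongly than the 4-chlorophenyl one. Nothing available accounts for this step.

Going by these compounds, it remains open how a fluoro, a methoxy or an amine at this position would read against hydrogen. On these data alone, it is also open whether removing the chloro would give a similar step on the core of compound 1.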